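Removing the isobutyl from compound 2: an opening

The source may hold more compounds than are shown below. What is called first, only, known or untested is meant among the compounds shown, and "the series" means these compounds.

Of the compounds shown here, two from this series have been tested in a functional assay on L929 cells (Mus musculus) for inhibition, read by MTT assay, with a stated time of 5 days; on this read-out higher numbers stand for weaker inhibition and lower numbers for stronger inhibition. Among the compounds with values here, compound 1 `COc1ccc(N(Cc2ccccc2)CC(C)C)cc1` gives 10 ug/mL in this assay, and compound 2 `COc1ccc(N(CC(C)C)CC(C)C)cc1` gives 25 ug/mL, which is the higher of the two numbers, the only other compound, compound 1, sitting a modest distance below it. Within the data shown here, the single known step is a 2.5-fold higher number from compound 1 to compound 2 (0.40 log units; beyond the scatter), a change on a saturated chain carbon bound to the aromatic nitrogen.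

Compound 3 `COc1ccc(NCC(C)C)cc1` goes one step further: hydrogen in place of isobutyl on a nitrogen on an aromatic ring, so that the nitrogen keeps only its aromatic carbon and the remaining isobutyl as neighbours. Among the measured compounds shown here, no measured pair tests this kind of removal directly; the step from compound 1 to compound 2 is the closest guide, and it was modest. A step of similar, modest size in this assay is therefore expected, most likely toward a higher number, and for compound 3 the expected result is 35 ug/mL, within a range from 12 ug/mL to 90 ug/mL, corresponding to a 1.4-fold higher number from compound 2 to compound 3 (0.15 log units; within the scatter).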

Compound 3, half-maximal inhibitory concentration: > 40 ug/mL
Compound 3 ended at the assay's limit; the forecaster's own chance of this, stated with the estimate: 10%; middle value at least 1.1-fold (0.05 log units) from the limit.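

In this assay, compound 3 gives > 40 ug/mL, which is a limit of the assay and not a number. Replacing an isobutyl with hydrogen on this nitrogen, the first change shown that removes a chain without putting another group in its place, brings no stronger inhibition and gives an at least 1.6-fold higher number from compound 2 to compound 3 (0.20 log units; that floor lies within the scatter). This step is only a floor, and its true size cannot be read because the value of compound 3 sits at the assay's limit: the limit of > 40 ug/mL in this assay, at which 1 of the 3 values shown sits.

On these data alone, how a small methyl group or a longer chain such as hexyl would read on this nitrogen, in place of the hydrogen of compound 3, stays open. So does the effect of a chain ending in an amine or a carboxylic acid at the same place.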